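The source may report more compounds than this note shows. Statements on the series, on what has been measured and on what is new or still open speak of the compounds shown alone.

Measured so far:
compound 1 `Cc1ccc(NC2=C(C(=O)c3ccccc3)C(c3ccc(Br)cc3)N(CCCn3ccnc3)C2=O)cc1` — 25800 nM
compound 2 `C[C@@H](NC1=C(C(=O)c2ccccc2)[C@@H](c2ccc(Br)cc2)N(CCCn2ccnc2)C1=O)c1ccccc1` — 14400 nM

In a functional assay on NCI-H1299 cells (Homo sapiens) for antiproliferative activity, read by MTT assay, with a stated time of 72 h (a lower number here means a stronger inhibitor, a higher number a weaker inhibitor), compound 1 gives 25800 nM and compound 2 gives 14400 nM; these two numbers lie within the usual scatter of each other, so neither compound is set apart. Compound 3 `C[C@@H](NC1=C(C(=O)c2ccccc2)[C@H](c2ccc(Br)cc2)N(CCCn2ccnc2)C1=O)c1ccccc1` keeps every atom and bond of compound 2 and differs only in configuration: the two compounds have the same atoms and bonds and differ only in configuration as drawn: 1 of 2 stereo elements differ; a stereocentre at a saturated ring carbon is drawn R in compound 2 and S in compound 3. Going by the values given here, no measured pair shows what such an inversion does here, so no direction is known; in this assay the expected step is a 1.0-fold higher number from compound 2 to compound 3 (0.02 log units; within the scatter), with either sign possible. Compound 3 is estimated at 15000 nM, with a range from 5000 nM to 45000 nM.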

Compound 3, half-maximal inhibitory concentration: 17000 nM
The estimate for compound 3 lay 1.1-fold (0.05 log units) below the measured number; the measured number falls inside the stated range.
By their numbers in this assay, from the lowest: compounds 2, 3 and 1 (each within the scatter of the next).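

In this assay, inverting the stereocentre at the saturated ring carbon from R to S comes with a 1.2-fold higher number from compound 2 to compound 3 (0.07 log units; within the scatter), so the assay does not separate these two configurations at this position. This pair gives the first measured read on such an inversion in the series, with the other stereo element drawn the same in both compounds. The comparison is a clean one: the fact that compounds 2 and 3 differ only in the configuration as drawn

Going by these compounds, the contribution of the other stereo element remains open. Also open, on these data alone, is whether this inversion would stay within the scatter in compounds carrying a carboxylic acid on the shared core.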